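Amide variation at the carbonyl of compound 1

A few compounds are considered here, and "the series" means these few. Any claim that something is new, unique, unknown or untested is made for them only; others in the source may bear on it.

Compound 1 `Nc1sc(-c2ccc(Cl)cc2)c(-c2ccc(Cl)cc2)c1C(=O)NCc1ccccc1` gives 16300 nM in a functional assay on A549 cells (Homo sapiens) for inhibition, read by sulforhodamine B assay, with a stated time of 72 h (a higher number here means a weaker inhibitor, a lower number a stronger inhibitor), the highest of the three numbers recorded. Compound 2 `Nc1sc(-c2ccc(Cl)cc2)c(-c2ccc(Cl)cc2)c1C(=O)NC1CC1` gives 1950 nM and compound 3 `COC(=O)c1c(N)sc(-c2ccc(Cl)cc2)c1-c1ccc(Cl)cc1` gives 5040 nM. The two measured steps from compound 1 both lower the number: an 8.4-fold lower number from compound 1 to compound 2 (0.92 log units; beyond the scatter) and a 3.2-fold lower number from compound 1 to compound 3 (0.51 log units; beyond the scatter). Compound 4 `Nc1sc(-c2ccc(Cl)cc2)c(-c2ccc(Cl)cc2)c1C(=O)N1CCOCC1` carries a change at the same carbonyl carbon: morpholin-4-yl in place of benzylamino on a carbonyl carbon. Both earlier replacements of the benzylamino or benzyl group moved the number down, so a modest step in the same direction is expected here, a 3.6-fold lower number from compound 1 to compound 4 (0.56 log units; beyond the scatter). Compound 4 is therefore estimated at 4500 nM, with a range from 1500 nM to 13000 nM.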

Compound 4, half-maximal inhibitory concentration: 1870 nM
Beside the measured number, compound 4's estimate is 2.4-fold (0.38 log units) above it, and the stated range covers the measured number.
By their numbers in this assay, from the lowest: compounds 4 and 2 (each within the scatter of the next); then compound 3; then compound 1.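

In this assay, morpholin-4-yl on the carbonyl carbon improves on two groups: an 8.7-fold lower number from compound 1 to compound 4 (0.94 log units; beyond the scatter), and a 2.7-fold lower number from compound 3 to compound 4 (0.43 log units; beyond the scatter). Cyclopropylamino keeps the amide hydrogen and morpholin-4-yl has none, yet the two cannot be separated, with a 1.0-fold lower number from compound 2 to compound 4 (0.02 log units; within the scatter), so reaching this level does not depend on that hydrogen in this pair. No available measurement accounts for these steps.

Open, from the compounds shown here alone, is whether dimethylamino or piperazin-1-yl on this carbonyl carbon would hold the number. Going by these compounds, a carboxylic acid at this place is equally open.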